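This account rests on a few compounds, and the source may have more. Where it says the series, first, only, none or still open, it means among the compounds named here.

Of the compounds shown here, two have numbers so far in an ADME assay on S9 fraction from liver (Homo sapiens) for metabolic stability, read by LC-MS, using NADPH, with stated times of 5 min and 60 min, tested at 5 uM; on this read-out higher numbers stand for a more stable compound and lower numbers for a less stable compound. Compound 1 `COc1cc(C2CN(C(=O)c3cc(OCCO)ccn3)C2)ccc1OCc1ccc(C2CC2)cc1` gives 47%, while compound 2 `COc1cc(C2CN(C(=O)c3cc(OCCCC(=O)O)ccn3)C2)ccc1OCc1ccc(C2CC2)cc1` gives 91%, the higher of the two. Going by the values given here, the only measured step, a number 44 percentage points higher from compound 1 to compound 2 (beyond the scatter), comes with carboxymethyl in place of hydroxy on a saturated chain carbon, two bonds along the chain from an oxygen on an aromatic ring.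

Compound 3 `COc1cc(C2CN(C(=O)c3cc(OCCCC(C)(C)C(=O)O)ccn3)C2)ccc1OCc1ccc(C2CC2)cc1` keeps the shared core and changes the same chain again: 1-carboxy-1-methylethyl in place of carboxy on a saturated chain carbon, three bonds along the chain from an oxygen on an aromatic ring. The entering group, 1-carboxy-1-methylethyl, still holds a carboxy, so this is a smaller edit than the swap of hydroxy for carboxymethyl. Among the compounds with values here, that large step therefore bears on the new change only loosely, and no measured compound carries the new group. The scale also leaves little room for a further rise, with compound 2 already at 91%. A fall remains possible, but nothing measured points to one, so no shift beyond the scatter is expected in this assay.

The estimated change is small: a number 3 percentage points lower from compound 2 to compound 3 (within the scatter). Compound 3 is expected at 88%, within an estimated range of 72% to 100%.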

Compound 3, percent of the compound remaining: 81%
Beside the measured number, compound 3's estimate is 7 percentage points above it, within the range that was stated.
By their numbers in this assay, from the lowest: compound 1; then compounds 3 and 2 (each within the scatter of the next).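

In this assay, swapping carboxy for 1-carboxy-1-methylethyl at this place on the chain, which takes the group from 3 to 6 heavy atoms, gives a number 10 percentage points lower from compound 2 to compound 3 (within the scatter) and so no shift that can be told from the usual scatter. The gain over the hydroxy chain also holds with the larger group, as 2-carboxy-2-methylpropyl in place of hydroxy gives a number 34 percentage points higher from compound 1 to compound 3 (beyond the scatter) and remains a large step. Going by these compounds alone, two different carboxy-bearing chains now stand clear of compound 1, the only compound here without a carboxy group, although three compounds are too few to support a general rule.

As far as these compounds go, whether the stability holds with a tetrazole or a primary amide in place of the carboxy, or with a longer chain leading to the carboxy, remains open. No further measurement here bears on why these steps have the size they do.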